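Methyl for chloro on the amide ring of compound 3

The compounds below may be only part of what the source reports. "The series", "measured", "known", "first", "only" and "open" are said of these compounds alone.

The three measured compounds share one core and differ only on the amine nitrogen in the ring. Compound 1 `NC(=O)c1c(NC(=O)c2ccccc2Cl)sc2c1CCN(Cc1cc(Cl)cc(Cl)c1)C2` gives 23700 nM in a functional assay on MKN-74 cells (Homo sapiens) for antiproliferative activity, with a stated time of 24 h; a higher number here means a weaker inhibitor, a lower number a stronger inhibitor. Compound 2 `NC(=O)c1c(NC(=O)c2ccccc2Cl)sc2c1CCN(C(=S)Nc1ccccc1F)C2` gives 12600 nM in this assay, and compound 3 `NC(=O)c1c(NC(=O)c2ccccc2Cl)sc2c1CCN(C(=S)Nc1ccccc1Br)C2` gives 10800 nM. Compound 3 has the lowest of the three numbers: the step of a 2.2-fold lower number from compound 1 to compound 3 (0.34 log units; beyond the scatter) is modest but beyond the scatter, while the step of a 1.2-fold lower number from compound 2 to compound 3 (0.07 log units; within the scatter) is within it, so compound 3 and compound 2 cannot be told apart on this assay.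

Compound 4 `Cc1ccccc1C(=O)Nc1sc2c(c1C(N)=O)CCN(C(=S)Nc1ccccc1Br)C2` keeps the ring-amine substituent of compound 3 and changes the other end of the molecule: methyl in place of chloro on an aromatic carbon. Among the measured compounds shown here, none of the measured steps touches that part of the molecule; the steps of a 1.9-fold lower number from compound 1 to compound 2 (0.27 log units; within the scatter) and a 2.2-fold lower number from compound 1 to compound 3 (0.34 log units; beyond the scatter) concern the ring amine only, and the step of a 1.2-fold lower number from compound 2 to compound 3 (0.07 log units; within the scatter) is within the scatter. For the measured compounds named here, no measured step therefore bears on this change, and nothing in the numbers points to a direction.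

Compound 4 is accordingly expected to sit close to compound 3, with a step of a 1.0-fold higher number from compound 3 to compound 4 (0.01 log units; within the scatter) that stays within the scatter. The estimate for compound 4 in this assay is 11000 nM, in a range from 4000 nM to 30000 nM.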

Compound 4, half-maximal inhibitory concentration: > 50000 nM
Compound 4 was reported as a limit; the forecaster's own chance of this, stated with the estimate: 5%; middle value at least 4.5-fold (0.65 log units) from the limit.
By their numbers in this assay, from the lowest: compounds 3, 2 and 1 (each within the scatter of the next, the first and the last beyond it). At a limit, above all of these: compound 4.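

Compound 4 is reported only as a limit of the assay, not as a number: the limit of > 50000 nM in this assay, at which 1 of the 4 values shown sits. Even so, the step of an at least 4.6-fold higher number from compound 3 to compound 4 (0.66 log units; beyond the scatter) shows that in this assay the end of the molecule away from the ring amine matters: a single heavy atom exchanged, methyl in place of chloro on an aromatic carbon ortho to a large group, is enough to move the result beyond the scatter. The earlier steps shown here all lay on the ring amine and reached no further than a 2.2-fold lower number from compound 1 to compound 3 (0.34 log units; beyond the scatter), so they gave no sign that 2-chlorophenyl could not be replaced by 2-methylphenyl without such a loss.

How far compound 4 lies past its limit remains unknown, so the step has only a lower bound, and nothing shown explains it. Also open, from the compounds shown here alone, is whether other groups at this place, such as fluoro, methoxy or an amine, would keep the number of compound 3, and whether the same exchange would act alike with the fluoro-bearing substituent of compound 2 on the ring amine.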